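The source may hold more compounds than are shown below. What is called first, only, known or untested is meant among the compounds shown, and "the series" means these compounds.

In an ADME assay on Vero cells (Chlorocebus sabaeus) for cytotoxicity, with a stated time of 5 days (on this read-out lower numbers stand for stronger inhibition and higher numbers for weaker inhibition), compound 1, with the structure `COc1nc(F)nc2c1ncn2[C@H]1C[C@H](N=[N+]=[N-])[C@@H](CO)O1`, gives > 100000 nM, which is a limit of the assay rather than a number. Compound 2, `COc1nc(Cl)nc2c1ncn2[C@H]1C[C@H](N=[N+]=[N-])[C@@H](CO)O1`, differs from it by one change: chloro in place of fluoro on an aromatic carbon. In this assay compound 2 also gives > 100000 nM, again a limit. The step that the two limits leave unreadable from compound 1 to compound 2 therefore cannot be read, because both values sit at the limit of > 100000 nM in this assay, at which 2 of the 3 values shown sit. Compound 3, `[N-]=[N+]=N[C@H]1C[C@H](n2cnc3c(N)nc(F)nc32)O[C@@H]1CO`, differs from compound 1 in another way: amino in place of methoxy on an aromatic carbon. In this assay, among the measured compounds shown here, compound 3 gives 34400 nM, the only number among the three measured compounds, and the step of an at least 2.9-fold lower number from compound 1 to compound 3 (0.46 log units; beyond the scatter) is read as at least modest.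

Compound 4, `[N-]=[N+]=N[C@H]1C[C@H](n2cnc3c(N)nc(Cl)nc32)O[C@@H]1CO`, has not yet been measured. It differs from compound 3 by chloro in place of fluoro on an aromatic carbon. This is the same kind of change as that from compound 1 to compound 2, though the surroundings are not identical: in compound 1 the place is meta to a methoxy group, whereas in compound 3 it is meta to an amino group. Since the earlier step of this kind was left unreadable by the two limits, the expectation for compound 4 rests mainly on the value of compound 3, and the step is estimated at a 1.2-fold higher number from compound 3 to compound 4 (0.07 log units; within the scatter). Compound 4 is thus expected to give about 40000 nM in this assay, somewhere between 15000 nM and 100000 nM.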

Compound 4, half-maximal inhibitory concentration: > 100000 nM
Compound 4: only a limit was reported; the forecaster's own chance of this, stated with the estimate: 25%; middle value at least 2.5-fold (0.39 log units) away from the limit.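

In this assay, chloro in place of fluoro on the core that carries the amino group gives an at least 2.9-fold higher number from compound 3 to compound 4 (0.46 log units; beyond the scatter); this size is only a lower bound, as compound 4 stands at a limit of the assay and not at a number. The same change on the core of compound 1 and the amino-for-methoxy step from compound 2 to compound 4 cannot be read, because both ends of each sit at the same limit: the limit of > 100000 nM in this assay, at which 3 of the 4 values shown sit. So the change is seen beyond the scatter on one core only, and the data neither confirm nor rule out a like step on the methoxy core.

The compounds shown leave open how far the read-out would move with bromo or a nitrile on that aromatic carbon, where fluoro and chloro are the only groups shown. They also leave open whether a primary amine in place of the azido group would alter the read-out on either core.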